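The compounds below may be only part of what the source reports. "The series", "measured", "known", "first", "only" and "open" are said of these compounds alone.

The measured compounds so far:
compound 1 `CC1C(=O)N(O)C(=O)c2ccccc21`, 250000 nM
compound 2 `O=C1c2ccccc2C(Cc2ccc(C(F)(F)F)cc2)C(=O)N1O`, 6000 nM
compound 3 `O=c1c2ccccc2c(Cc2ccccc2)c(O)n1O`, 88000 nM

In an ADME assay on MT4 cells (Homo sapiens) for cytotoxicity, read by MTT assay (on this read-out higher numbers stand for lower toxicity in this test and lower numbers for higher toxicity in this test), compound 1 gives 250000 nM, the highest of the three numbers. Compound 3 comes nearest to it with 88000 nM, and compound 2 stands furthest away at 6000 nM. Both gaps lie beyond the scatter, so compound 1 is the least toxic of the three in this test.

The account now turns to compound 4 `Cc1ccc(CC2C(=O)N(O)C(=O)c3ccccc32)cc1`, which has not yet been measured. It differs from compound 1 in one place: 4-methylphenyl in place of hydrogen on a saturated chain carbon bound to a saturated ring carbon. Among the compounds with values here, no measured pair shows this exact change, so the direction can only be read from the wider set. Compound 2 and compound 3, each carrying more than compound 1 does, both give lower numbers than compound 1, and so a step downward in this assay, beyond the scatter, is expected, a 13-fold lower number from compound 1 to compound 4 (1.10 log units; beyond the scatter). Compound 4 is accordingly estimated at 20000 nM, with a range from 5000 nM to 80000 nM, placed between the numbers of compound 2 and compound 3 because compound 2 gives 6000 nM on the same core.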

Compound 4, half-maximal cytotoxic concentration: 5500 nM
Estimate against measurement, compound 4: 3.6-fold (0.56 log units) above, within the range that was stated.
By their numbers in this assay, from the lowest: compounds 4 and 2 (each within the scatter of the next); then compound 3; then compound 1.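

In this assay, within the data shown here, 4-methylphenyl in place of hydrogen on a saturated chain carbon bound to a saturated ring carbon gives a 45-fold lower number from compound 1 to compound 4 (1.66 log units; beyond the scatter), the first single change at this position that can be read directly, and a large one. Methyl in place of trifluoromethyl on an aromatic carbon gives a 1.1-fold lower number from compound 2 to compound 4 (0.04 log units; within the scatter), so in this test the two groups cannot be told apart at that place, and the large step does not depend on which of them the ring carries. Nothing at hand accounts for either step.

The compounds shown leave open how much of the large step comes from the aromatic ring alone and how much from the group it carries. They also leave open whether an amine or a carboxylic acid on that aromatic carbon, or a longer chain at the saturated chain carbon, would give a similar number.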